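This account rests on a few compounds, and the source may have more. Where it says the series, first, only, none or still open, it means among the compounds named here.

Working notes on the series.

Compound 1 `O=C(O)c1cc(CCCCNS(=O)(=O)c2ccccc2)c2cccccc1-2` is the reference point. In a functional assay (thoracic aorta) for inhibition, with Rattus norvegicus as the target (on this read-out lower numbers stand for stronger inhibition and higher numbers for weaker inhibition), compound 1 gives 570 nM. Compound 2 `O=C(O)c1cc(CCCCCNS(=O)(=O)c2ccccc2)c2cccccc1-2` carries a longer chain between the shared core and the sulfonamide; how the two cores differ is not broken down here. In this assay compound 2 gives 840 nM, and the two values sit within the usual scatter of each other, so nothing can be said about an order between compound 1 and compound 2.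

Compound 3 `CC(C)c1cccc2c(CCCCNS(=O)(=O)c3ccccc3)cc(C(=O)O)c-2c1` is compound 1 with one change, marked (isopropyl in place of hydrogen on an aromatic carbon). In this assay compound 3 gives 3100 nM, which is a 5.4-fold higher number from compound 1 to compound 3 (0.74 log units; beyond the scatter). Within the data shown here, this is the only measured step in the set, and it points toward weaker inhibition once the isopropyl is present on the aromatic carbon.

Compound 4 `CC(C)c1cccc2c(CCCCCNS(=O)(=O)c3ccccc3)cc(C(=O)O)c-2c1` is not yet measured. It stands to compound 2 exactly as compound 3 stands to compound 1; the change is marked (isopropyl in place of hydrogen on an aromatic carbon), and the two descriptions of the place agree word for word, so this is the same change made on the core of compound 2. The expectation rests on one observation only and on the fact that compound 1 and compound 2 are not separated beyond the scatter in this assay.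

The step from compound 2 to compound 4 in this assay is expected to be a 5.4-fold higher number from compound 2 to compound 4 (0.73 log units; beyond the scatter), because of a 5.4-fold higher number from compound 1 to compound 3 (0.74 log units; beyond the scatter). For compound 4 in this assay the estimated value is 4500 nM, with an expected span from 2000 nM to 10000 nM.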

Compound 4, half-maximal inhibitory concentration: 2600 nM
The estimate for compound 4 lay 1.7-fold (0.24 log units) above the measured number; measured number inside the range.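

On the core with the longer chain, isopropyl in place of hydrogen on an aromatic carbon gives a 3.1-fold higher number from compound 2 to compound 4 (0.49 log units; beyond the scatter) in this assay, which is in the same direction as the step on the core of compound 1. Set side by side, the two steps are not separated in size: the same change on two cores in this assay, a 5.4-fold higher number (0.74 log units; beyond the scatter) from compound 1 to compound 3 and a 3.1-fold higher number (0.49 log units; beyond the scatter) from compound 2 to compound 4, 1.8-fold (0.24 log units) apart, within the scatter of two such steps. This shows that the change carries across these two cores with the same direction and without a separable difference in size, but two pairs in one assay do not establish a rule for other cores, and they do not show why the number rises or whether the small gap between the two steps has any meaning.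

The compounds shown leave open whether methyl, tert-butyl, chlorine or an amine on the same aromatic carbon would give a step of this kind, since isopropyl is the only group seen there. From the compounds shown here alone, it also remains open whether the step holds with a shorter or still longer chain, or with an amide or a tetrazole in place of the carboxylic acid.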